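Replacing phenyl with methoxy at an assay limit

The source may hold more compounds than are shown below. What is called first, only, known or untested is meant among the compounds shown, and "the series" means these compounds.

Compound 1 `CCOC(=O)c1c(-c2cccc(OC)c2)[nH]c2cc(OC)c(OC)cc2c1=O`: > 21500 nM, a limit
Compound 2 `CCOC(=O)c1c(-c2cccc(-c3ccccc3)c2)[nH]c2cc(Cl)c(OC)cc2c1=O`: > 21500 nM, a limit

In an ADME assay on BJ cells (Homo sapiens) for cytotoxicity, read by luminescence, with a stated time of 72 h (a higher number here means that more compound is needed for the effect, a lower number that less compound is needed), compound 2 gives > 21500 nM, which is a limit of the assay and not a number. Compound 2 therefore has no exact position on the scale, and neither does compound 1, so no order can be drawn between them. What has been measured so far comes down to the limit of > 21500 nM in this assay, at which 2 of the 2 values shown sit.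

Compound 3 `CCOC(=O)c1c(-c2cccc(OC)c2)[nH]c2cc(Cl)c(OC)cc2c1=O` has not yet been measured. It follows from compound 2 by placing methoxy in place of phenyl on an aromatic carbon, meta to a large group: methoxy in place of phenyl on an aromatic carbon. Within the data shown here, no step between measured compounds is available to gauge this change directly. The expectation therefore rests on the limit of compound 2, > 21500 nM, and no change beyond the scatter is expected in either direction in this assay. The expected step is a step that the limit leaves unreadable from compound 2 to compound 3. Compound 3 is estimated at 22000 nM, with an expected range from 12000 nM to 40000 nM, and it will most likely be reported only as a limit.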

Compound 3, half-maximal effective concentration: > 21500 nM
Compound 3 ended at the assay's limit (the forecaster's own chance of this, stated with the estimate: 85%); the middle value is on the limit's open side.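

In this assay compound 3 gives > 21500 nM, which is a limit of the assay and not a number. Compound 1 and compound 2 also sit at limits, so neither step to compound 3 can be read. The compounds shown leave open what methoxy in place of phenyl, or chloro in place of methoxy, does here.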